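The compounds below may be only part of what the source reports. "The series", "measured", "known", "first", "only" and "open" are said of these compounds alone.

Of the compounds shown here, two sharing one core have been tested in an assay for binding affinity to adenosine receptor A1 (Rattus norvegicus), read by radioligand binding; a higher number here means a weaker inhibitor, a lower number a stronger inhibitor. Compound 1 `C=CCn1c(=O)c2c(nc(-c3ccccc3)n2C)n(C)c1=O` carries a phenyl group and an allyl group that compound 2 lacks; in this assay compound 1 gives 9000 nM. Compound 2 `Cc1nc2c(=O)n(C)c(=O)n(C)c2[nH]1` instead has a methyl on the aromatic carbon of its five-membered ring; in this assay compound 2 gives 8800 nM. These two values lie within the usual scatter of each other, so neither compound can be called the stronger or weaker binder, and both sit at the weak end of what such an assay resolves.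

Compound 3 `Cn1c(=O)c2nc(C3CCC3)[nH]c2n(C)c1=O` has not yet been measured. It differs from compound 2 in a single place: cyclobutyl in place of methyl on an aromatic carbon. Among the measured compounds shown here, no pair of measured compounds shows what this particular exchange does here, so the expectation rests on the change itself. A step toward stronger binding, clearly beyond the scatter, is expected, amounting to a 110-fold lower number from compound 2 to compound 3 (2.04 log units; beyond the scatter). Compound 3 is accordingly estimated at 80 nM, with a likely range from 15 nM to 400 nM.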

Compound 3, inhibition constant: 190 nM
Beside the measured number, compound 3's estimate is 2.4-fold (0.38 log units) below it; measured number inside the range.
By their numbers in this assay, from the lowest: compound 3; then compounds 2 and 1 (each within the scatter of the next).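

In this assay, among the compounds shown here, the exchange of methyl for cyclobutyl on the aromatic carbon between two ring nitrogen atoms gives a 46-fold lower number from compound 2 to compound 3 (1.67 log units; beyond the scatter) and so provides the first single-place step here that lies beyond the scatter, showing that the number in this assay is sensitive to what this position carries. The change is purely one of carbon framework: the methyl that leaves has 1 heavy atom and no ring, the cyclobutyl that enters has 4 heavy atoms and one four-membered non-aromatic ring, and neither group has hydrogen-bond donors or acceptors or a net charge. No supporting measurement is available to explain how this exchange produces so large a step.

A single step cannot separate the effect of having a ring from that of simply having more carbon, so an ethyl group, a longer chain, or a cyclopropyl or cyclopentyl ring at the same place would be needed to tell these apart. Also open, as far as these compounds go, is how this position would respond to a group containing nitrogen or oxygen, such as an amine or an ether.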